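A few compounds are considered here, and "the series" means these few. Any claim that something is new, unique, unknown or untested is made for them only; others in the source may bear on it.

Measured compounds in a functional assay on HCT-8 cells (Homo sapiens) for antiproliferative activity, read by MTT assay, with a stated time of 48 h; a higher number here means a weaker inhibitor, a lower number a stronger inhibitor:

- compound 1, `C=C(c1ccc(OC)cc1NC(=O)CO)c1ccc(OC)c2c1C=CC(C)(C)O2`: compound 1 gives 470 nM
- compound 2, `C=C(c1cc(OC)c(OC)c(OC)c1)c1ccc(OC)cc1NC(=O)CO`: compound 2 gives 40 nM
- compound 3, `C=C(c1ccc(OC)cc1NC(=O)CN)c1ccc(OC)c2c1C=CC(C)(C)O2`: compound 3 gives 520 nM

Compound 2 gives the lowest number of the three in this assay, and its gaps to compound 1 and to compound 3 both lie beyond the usual scatter. The difference between the core of compound 2 and the shared core of compounds 1 and 3 is not broken down here.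

Compounds 1 and 3 differ in one place, (amino in place of hydroxy on a saturated chain carbon bound to a carbonyl carbon), and the step in this assay is a 1.1-fold higher number from compound 1 to compound 3 (0.04 log units; within the scatter), within the scatter.

Compound 4, `C=C(c1cc(OC)c(OC)c(OC)c1)c1ccc(OC)cc1NC(=O)CN`, carries the same change on the core of compound 2: amino in place of hydroxy on a saturated chain carbon bound to a carbonyl carbon. The place of the change is identical in both pairs, so this is the same change, seen once on each core.

Among the measured compounds shown here, for compound 4 the step from compound 2 is estimated at a 1.1-fold higher number from compound 2 to compound 4 (0.05 log units; within the scatter) in this assay, because a 1.1-fold higher number from compound 1 to compound 3 (0.04 log units; within the scatter) is the single precedent for this change and lies within the scatter. Compound 4 is therefore expected near 45 nM, with the estimate spanning 20 nM to 110 nM.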

Compound 4, half-maximal inhibitory concentration: 60 nM
The estimate for compound 4 lay 1.3-fold (0.12 log units) below the measured number, and the stated range covers the measured number.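

In this assay, amino in place of hydroxy on a saturated chain carbon bound to a carbonyl carbon gives a 1.5-fold higher number from compound 2 to compound 4 (0.18 log units; within the scatter), and the two cores carrying this change do not differ in their steps: the same change on two cores in this assay, a 1.1-fold higher number (0.04 log units; within the scatter) from compound 1 to compound 3 and a 1.5-fold higher number (0.18 log units; within the scatter) from compound 2 to compound 4, 1.4-fold (0.13 log units) apart, within the scatter of two such steps.

Within this series, the near-absence of a step seen on the core of compound 1 therefore also holds on the core of compound 2, and neither pair shows the exchange of hydroxy for amino moving the number beyond the scatter. This does not show that the change is neutral in general: the evidence is two pairs on two cores in one assay, a small real step could lie hidden within the scatter, and nothing here explains why the steps match.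

The compounds shown leave open how a dimethylamino group or a carboxylic acid at the same place, or a longer chain carrying the amino group, would read in this assay. From the compounds shown here alone, whether the same step holds on a third core also remains open.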